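This account rests on a few compounds, and the source may have more. Where it says the series, first, only, none or still open, it means among the compounds named here.

The measured compounds in an assay on isolated protein (Mus musculus) for inhibition of IL15-IL15 receptor (Homo sapiens), read by resazurin assay, with stated times of 30 min and 2.5 days; a lower number here means a stronger inhibitor, a higher number a weaker inhibitor:

Compound 1 `Cn1c(Cc2nn(C)c(=O)c3ccccc23)nnc1SCC(=O)Nc1ccc(I)cc1` gives "not active" (no number reported).
Compound 2 `CCCCCCCCCCSc1nnc(Cc2nn(C)c(=O)c3ccccc23)n1C` gives 7600 nM.
Compound 3 `Cc1ccc(NC(=O)CCCCCCCSc2nnc(Cc3nn(C)c(=O)c4ccccc34)n2C)c(Cl)c1` gives 2300 nM.

Compound 1 thus has no number of its own; it was reported only as not active, so it cannot be placed against compound 2 or compound 3 on a scale. Compound 4 `COc1ccc(NC(=O)CSc2nnc(Cc3nn(C)c(=O)c4ccccc34)n2C)cc1` differs from compound 1 in one spot: methoxy in place of iodo on an aromatic carbon. Going by the values given here, no measured pair touches this spot. Among the compounds with values here, the only measured step, a 3.3-fold lower number from compound 2 to compound 3 (0.52 log units; beyond the scatter), concerns the chain end and says nothing about exchanging groups on the aromatic ring. Given that compound 1 showed no activity and nothing supports a gain, compound 4 is expected to remain weak in this assay, estimated at 15000 nM, within 3000 nM to 80000 nM.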

Compound 4, half-maximal inhibitory concentration: "not active" (no number reported)
No number was reported for compound 4; no gap can be computed for the estimate.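

Compound 1 and compound 4 were both reported as not active, without a number, so no step can be read between them. These compounds leave open whether iodo and methoxy differ in effect at this spot on the ring. No supporting evidence bears on this result.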